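The source may report more compounds than this note shows. Statements on the series, on what has been measured and on what is new or still open speak of the compounds shown alone.

Measured so far:
- Compound 1 `N#Cc1cnc(NCc2cnccc2C(F)(F)F)cc1NC[C@H]1C[C@@H](O)C1` gives 300 nM in an assay on isolated protein for inhibition of protein kinase C theta type (Homo sapiens), read by TR-FRET, with a stated time of 2 h; on this read-out higher numbers stand for weaker inhibition and lower numbers for stronger inhibition.
- Compound 2 `CO[C@H]1CC[C@H](CNc2cc(NCc3cnccc3C(F)(F)F)ncc2C#N)CC1` gives 330 nM in this assay.

Among the measured compounds shown here, compound 2 has the higher of the two numbers, but the one step that joins it to compound 1, a 1.1-fold higher number from compound 1 to compound 2 (0.04 log units; within the scatter), lies within the scatter, so the two cannot be ordered. Compound 3 `N#Cc1cnc(NCc2cnccc2C(F)(F)F)cc1NCC1CCOCC1` differs from compound 2 by oxan-4-yl in place of 4-methoxycyclohexyl on a saturated chain carbon bound to a nitrogen on an aromatic ring. For the measured compounds named here, only that step bears on the change, and it barely moved the number. No step beyond the scatter is therefore expected for compound 3, giving an estimated 1.1-fold higher number from compound 2 to compound 3 (0.03 log units; within the scatter). Compound 3 is expected at 350 nM, with a range from 150 nM to 800 nM.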

Compound 3, half-maximal inhibitory concentration: 400 nM
The estimate for compound 3 lay 1.1-fold (0.06 log units) below the measured number, within the range that was stated.
By their numbers in this assay, from the lowest: compounds 1, 2 and 3 (each within the scatter of the next).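

At this place, on a saturated chain carbon bound to a nitrogen on an aromatic ring, oxan-4-yl can be told apart from neither earlier group: the steps, a 1.2-fold higher number from compound 2 to compound 3 (0.08 log units; within the scatter) and a 1.3-fold higher number from compound 1 to compound 3 (0.12 log units; within the scatter), both stay within the scatter. The three compounds therefore cannot be ordered, whether the ring is 3-hydroxycyclobutyl, 4-methoxycyclohexyl or oxan-4-yl. Nothing available explains this lack of separation.

The compounds shown leave open whether this place tolerates every group equally. An amine such as piperidin-4-yl, a carboxylic acid or an open longer chain could still give a different number.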